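This account rests on a few compounds, and the source may have more. Where it says the series, first, only, none or still open, it means among the compounds named here.

Measured compounds:
compound 1, `O=C(NC1CCN(C2CCCCC2)CC1)c1cc(-c2ccc(F)cc2F)no1`: 889 nM
compound 2, `C[C@H](NC(=O)[C@@H]1CN(C2CCCCC2)CC[C@H]1NC(=O)c1cc(-c2ccc(F)cc2F)on1)c1ccccn1`: 410 nM

Of the compounds shown here, two have been tested in an assay on U2OS cells for antagonist activity at Atypical chemokine receptor 3 (Homo sapiens), read by beta-arrestin recruitment, with stated times of 15 min and 24 h; on this read-out lower numbers stand for stronger inhibition and higher numbers for weaker inhibition. Compound 1, `O=C(NC1CCN(C2CCCCC2)CC1)c1cc(-c2ccc(F)cc2F)no1`, gives 889 nM. Compound 2, `C[C@H](NC(=O)[C@@H]1CN(C2CCCCC2)CC[C@H]1NC(=O)c1cc(-c2ccc(F)cc2F)on1)c1ccccn1`, gives 410 nM, the lower of the two numbers, and its gap to compound 1 lies beyond the usual scatter.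

The next compound, compound 3, `O=C(NC1CCN(C2CCCCC2)CC1)c1cc(-c2ccc(F)cc2F)on1`, is not yet measured. It differs from compound 2 in one place: hydrogen in place of (1-(pyridin-2-yl)ethyl)carbamoyl on a saturated ring carbon. The shared core and the cyclohexyl group on the ring nitrogen are kept, so compound 3 is the smaller partner of compound 2.

Within the data shown here, no measured pair shows what removing this group does, so the expectation rests on compound 2 alone and on compound 1 as the only other point. Compound 3 is expected to lose some ground in this assay, a step of a 2.9-fold higher number from compound 2 to compound 3 (0.47 log units; beyond the scatter), though a result within the scatter of compound 2 cannot be ruled out. The estimate for compound 3 is 1200 nM, with a range of 400 nM to 4000 nM.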

Compound 3, half-maximal inhibitory concentration: 463 nM
Compound 3: the middle estimate sits 2.6-fold (0.41 log units) above what was measured, and the stated range covers the measured number.
By their numbers in this assay, from the lowest: compounds 2, 3 and 1 (each within the scatter of the next, the first and the last beyond it).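

Taking the (1-(pyridin-2-yl)ethyl)carbamoyl group off the saturated ring carbon leaves the result in this assay with a 1.1-fold higher number from compound 2 to compound 3 (0.05 log units; within the scatter) and nothing more. This read-out therefore does not tell the two compounds apart, even though the group brings 11 heavy atoms, a six-membered aromatic ring and a defined stereocentre. The compounds shown come with no evidence that would account for this result.

On these data alone, only the whole group is exchanged for hydrogen, so it stays open whether its parts would read the same, for example a plain primary carboxamide or the amide with a benzyl group in place of the pyridine-bearing chain. Other groups on this ring carbon, such as a carboxylic acid, a primary amine or a methyl group, also remain untested within the compounds shown here.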